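A few compounds are considered here, and "the series" means these few. Any claim that something is new, unique, unknown or untested is made for them only; others in the source may bear on it.

Measured so far in a functional assay on HEK293 cells for agonist activity at Vasopressin V2 receptor (Homo sapiens), read by a luciferase reporter and cAMP accumulation; on this read-out higher numbers stand for an effect only at larger amounts of compound and lower numbers for an effect already at smaller amounts:
Compound 1 `COC(=O)CNC(=O)NCc1ccc(C(=O)N2CCCCc3ccccc32)cc1C` gives 37 nM.
Compound 2 `CO[C@@H]1C[C@@H](C(=O)N(C)C)N(C(=O)NCc2ccc(C(=O)N3CCCCc4ccccc43)cc2C)C1` gives 4.7 nM.

Compound 2 holds the lowest of the two numbers; its nearest neighbour is compound 1, and the step of a 7.9-fold lower number from compound 1 to compound 2 (0.90 log units; beyond the scatter) lies beyond the scatter. Compound 3 `Cc1cc(C(=O)N2CCCCc3ccccc32)ccc1CNC(=O)N1CC(=O)C[C@H]1C(=O)N(C)C` differs from compound 2 by 2-(dimethylcarbamoyl)-4-oxopyrrolidin-1-yl in place of 2-(dimethylcarbamoyl)-4-methoxypyrrolidin-1-yl on a carbonyl carbon. Going by the values given here, no measured step covers this exchange: the single known step replaces the whole substituent on the carbonyl carbon and carries no information on trading the methoxy for an oxo group on the pyrrolidinyl ring. For compound 3 a step of a 1.7-fold higher number from compound 2 to compound 3 (0.23 log units; within the scatter) is expected, not clearly beyond the scatter. Compound 3 is therefore estimated at 8 nM, range 2.5 nM to 30 nM, in this assay.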

Compound 3, half-maximal effective concentration: 27 nM
Beside the measured number, compound 3's estimate is 3.4-fold (0.53 log units) below it; measured number inside the range.
By their numbers in this assay, from the lowest: compound 2; then compounds 3 and 1 (each within the scatter of the next).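

In this assay, on the carbonyl carbon whose other neighbour is the amide-type nitrogen, the pyrrolidinyl substituent is sensitive to what it carries: oxo in place of methoxy gives a 5.7-fold higher number from compound 2 to compound 3 (0.76 log units; beyond the scatter) in this series. Against the open-chain group, a 1.4-fold lower number from compound 1 to compound 3 (0.14 log units; within the scatter) shows that the 2-(dimethylcarbamoyl)-4-oxopyrrolidin-1-yl group gives no readable difference, so among these compounds the pyrrolidinyl ring alone does not account for the low number of compound 2.

Whether a hydroxyl group or a plain hydrogen in place of the methoxy would hold that number stays open, and no measured data here explain the step.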